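Carbonyl substituents in the series: from cyclopropyl to pyridin-4-yl

The source may hold more compounds than are shown below. What is called first, only, known or untested is meant among the compounds shown, and "the series" means these compounds.

Two compounds share one core and differ in the group on a carbonyl carbon: compound 1 `C=C1C(=O)O[C@H]2CC3=C[C@H](C/C(C)=C/[C@@H](OC(=O)c4ccc([N+](=O)[O-])cc4)[C@H]12)OC3=O` carries 4-nitrophenyl, and compound 2 `C=C1C(=O)O[C@H]2CC3=C[C@H](C/C(C)=C/[C@@H](OC(=O)C4CC4)[C@H]12)OC3=O` carries cyclopropyl. In a functional assay on NCI-H460 cells (Homo sapiens) for cytotoxicity, read by MTT assay, with a stated time of 48 h (a lower number here means a stronger inhibitor, a higher number a weaker inhibitor), compound 1 gives > 10000 nM, which is a limit of the assay and not a number. For the measured compounds named here, compound 2 gives 3000 nM, the only actual number so far in this assay. Going by the values given here, the one measured step is an at least 3.3-fold lower number from compound 1 to compound 2 (0.52 log units; beyond the scatter), and it comes with cyclopropyl replacing 4-nitrophenyl.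

Compound 3 `C=C1C(=O)O[C@H]2CC3=C[C@H](C/C(C)=C/[C@@H](OC(=O)c4ccncc4)[C@H]12)OC3=O` keeps the core and brings the change (pyridin-4-yl in place of cyclopropyl on a carbonyl carbon). This returns a six-membered aromatic ring to the carbonyl carbon, as in compound 1, though with a different group. Among the compounds with values here, with only the step of an at least 3.3-fold lower number from compound 1 to compound 2 (0.52 log units; beyond the scatter) to go on, part of that step is expected to be given back. The expected step is a 2.3-fold higher number from compound 2 to compound 3 (0.37 log units; beyond the scatter), in the direction of weaker inhibition, and a result reported only as a limit remains possible. In this assay the estimated value for compound 3 is 7000 nM, with an expected range from 2500 nM to 15000 nM.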

Compound 3, half-maximal inhibitory concentration: 5600 nM
Compound 3: middle estimate off by 1.3-fold (0.10 log units), on the high side; measured number inside the range.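

In this assay, the step to a six-membered aromatic ring with one hetero atom on this carbonyl carbon is a 1.9-fold higher number from compound 2 to compound 3 (0.27 log units; within the scatter), so pyridin-4-yl and cyclopropyl cannot be separated at this place. An aromatic ring here therefore does not in itself bring the limit seen with 4-nitrophenyl: compound 1 gives > 10000 nM, which is a limit of the assay and not a number. Set against that limit, the change from 4-nitrophenyl to pyridin-4-yl reads as an at least 1.7-fold lower number from compound 1 to compound 3 (0.25 log units; that floor lies within the scatter), so the two aromatic groups cannot be placed in order, and the true size of the gap stays unknown: the limit of > 10000 nM in this assay, at which 1 of the 3 values shown sits.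

The compounds shown leave open how far the group on this carbonyl carbon can move the number in this assay, as the two measured members sit within the scatter of each other and the third is only a limit. Also open, on these data alone, is how an unsubstituted phenyl, a longer alkyl chain or a group carrying an amine would read at this place on the shared core.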